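A Level Series Meets an Acetyl Group

The source may report more compounds than this note shows. Statements on the series, on what has been measured and on what is new or still open speak of the compounds shown alone.

In a functional assay on Hs 683 cells (Homo sapiens) for inhibition, read by MTT assay, with a stated time of 72 h (a lower number here means a stronger inhibitor of growth, a higher number a weaker inhibitor of growth), compound 3 `CC1(C)CCC[C@]2(C)[C@@H](C=O)C(/C=C/C#N)=CC[C@@H]12` gives 28000 nM. Compound 1 `CCOC(=O)/C=C/C1=CC[C@H]2C(C)(C)CCC[C@]2(C)[C@H]1C=O` gives 29000 nM, and compound 2 `CC1(C)CCC[C@]2(C)[C@@H](C=O)C(/C=C/C(=O)OCc3ccccc3)=CC[C@@H]12` gives 31000 nM. All three stand within the scatter of one another, so compound 3 holds no distinct place among them.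

Compound 4 `CC(=O)/C=C/C1=CC[C@H]2C(C)(C)CCC[C@]2(C)[C@H]1C=O` carries acetyl in place of cyano on a double-bonded chain carbon bound to a double-bonded chain carbon.

Going by the values given here, two measured steps bear on this change. Cyano in place of ethoxycarbonyl gave a 1.0-fold lower number from compound 1 to compound 3 (0.02 log units; within the scatter), and phenyl in place of methyl gave a 1.1-fold higher number from compound 1 to compound 2 (0.03 log units; within the scatter). On that evidence, no step beyond the scatter is expected in this assay. The expected step is a 1.0-fold higher number from compound 3 to compound 4 (0.02 log units; within the scatter). The estimate for compound 4 is 29000 nM, with an expected range of 15000 nM to 55000 nM.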

Compound 4, concentration for 50% growth inhibition: 22000 nM
Beside the measured number, compound 4's estimate is 1.3-fold (0.12 log units) above it, and the stated range covers the measured number.
By their numbers in this assay, from the lowest: compounds 4, 3, 1 and 2 (each within the scatter of the next).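

In this assay acetyl in place of cyano gives a small step (a 1.3-fold lower number from compound 3 to compound 4 (0.10 log units; within the scatter)), methyl in place of ethoxy on a carbonyl carbon gives another (a 1.3-fold lower number from compound 1 to compound 4 (0.12 log units; within the scatter)), and methyl in place of benzyloxy on a carbonyl carbon gives a third (a 1.4-fold lower number from compound 2 to compound 4 (0.15 log units; within the scatter)). The level series thus extends to a fourth group at this place, acetyl, and all three steps stay within the scatter. No measurement available explains these small steps.

As far as these compounds go, what a carboxylic acid or an amine would do at this place stays open. So does whether any group here can move the number beyond the scatter.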